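The source may hold more compounds than are shown below. What is called first, only, known or untested is meant among the compounds shown, and "the series" means these compounds.

Measured compounds:
compound 1 `C=CCOC(=O)Nc1ccc([Se]C#N)cc1` with 72800 nM
compound 2 `N#C[Se]c1ccc(NC(=O)OCC2=Cc3ccccc3S2(=O)=O)cc1` with 74300 nM

Two members of this series carry a number in a functional assay on HT-29 cells (Homo sapiens) for cytotoxicity, read by MTT assay, with a stated time of 72 h; on this read-out higher numbers stand for lower toxicity in this test and lower numbers for higher toxicity in this test. Compound 1 gives 72800 nM there, the lowest of the two numbers. Its nearest neighbour is compound 2, which gives 74300 nM in this assay; the two values lie within the scatter of each other, so no order between compound 1 and compound 2 can be read from them. For the measured compounds named here, no step between two measured compounds that differ in one place is available, so the size of a single change has not been seen.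

Compound 3 `CCCCCCOC(=O)Nc1ccc([Se]C#N)cc1` is not yet measured. It differs from compound 1 as follows: pentyl in place of vinyl on a saturated chain carbon bound to an oxygen next to a carbonyl group. The carbamate and the shared core are kept. Nothing in the measured pairs speaks for a shift beyond the scatter from this change; the expected step of a 1.0-fold lower number from compound 1 to compound 3 (0.02 log units; within the scatter) is therefore small, with no preferred direction. Compound 3 is estimated at 70000 nM in this assay, with a range from 35000 nM to 140000 nM.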

Compound 3, concentration lethal to 50% of the cells: 69900 nM
Compound 3: the middle estimate sits 1.0-fold (0.00 log units) above what was measured; low and high end bracket the measured number.
By their numbers in this assay, from the lowest: compounds 3, 1 and 2 (each within the scatter of the next).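

In this assay, for the compounds shown here, the first single-place step is a 1.0-fold lower number from compound 1 to compound 3 (0.02 log units; within the scatter) and so stays within the scatter. At this saturated chain carbon bound to an oxygen next to a carbonyl group, the double bond outside aromatic rings can therefore be lost and vinyl lengthened to pentyl, the same difference as allyl to hexyl, without a shift beyond the scatter in this read-out. No independent measurement bears on this result, and the step gives size only, with nothing to account for it.

Going by these compounds alone, whether a chain longer than hexyl, a branched alkyl chain, or a chain ending in an amine or a carboxylic acid would leave the number equally unmoved remains open, since vinyl and pentyl are the only pair compared here and neither carries a hydrogen-bond donor or acceptor. Within the data shown here, no single-place step links compound 2 to compound 1 or compound 3, so the flat result for the two chains cannot be extended to the group carried by compound 2.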